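A Much Longer Chain on Compound 3

A few compounds are considered here, and "the series" means these few. Any claim that something is new, unique, unknown or untested is made for them only; others in the source may bear on it.

- compound 1 `COc1ccc(-c2c(C)[nH]c(=O)n2C2CCCCC2)cc1` gives 20400 nM
- compound 2 `CCCCCc1ccc(-c2c(C)[nH]c(=O)n2C2CCCCC2)cc1` gives 10600 nM
- compound 3 `CCCCCCCOc1ccc(-c2c(C)[nH]c(=O)n2C2CCCCC2)cc1` gives 11600 nM

These values come from a functional assay on brain (Rattus norvegicus, strain Wistar) for inhibition; a lower number here means a stronger inhibitor, a higher number a weaker inhibitor. All three compounds share one core and differ only in the group on its aromatic ring. Compound 3 does not separate from the other two: the steps of a 1.8-fold lower number from compound 1 to compound 3 (0.25 log units; within the scatter) and a 1.1-fold higher number from compound 2 to compound 3 (0.04 log units; within the scatter) both lie within the scatter, as does a 1.9-fold lower number from compound 1 to compound 2 (0.28 log units; within the scatter).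

The next compound, compound 4 `CCCCCCCCCCCCCCCCCCOc1ccc(-c2c(C)[nH]c(=O)n2C2CCCCC2)cc1`, has undecyl in place of hydrogen on a saturated chain carbon, seven bonds along the chain from an oxygen on an aromatic ring.

Within the data shown here, the closest precedent is the hexyl added to the methoxy group, a 1.8-fold lower number from compound 1 to compound 3 (0.25 log units; within the scatter), which did not move the value beyond the scatter. Replacing pentyl with heptyloxy, a 1.1-fold higher number from compound 2 to compound 3 (0.04 log units; within the scatter), did not do so either. On that evidence, no clear change in either direction is expected, although undecyl is a much larger addition than any measured so far, so the range must stay wide.

The expected change is a 1.2-fold lower number from compound 3 to compound 4 (0.06 log units; within the scatter), which is a step no larger than the scatter.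

For compound 4 the estimate is 10000 nM, with an expected range from 2500 nM to 40000 nM.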

Compound 4, half-maximal inhibitory concentration: > 100000 nM
Compound 4 ended at the assay's limit (the forecaster's own chance of this, stated with the estimate: 15%); middle value at least 10-fold (1.00 log units) from the limit.
By their numbers in this assay, from the lowest: compounds 2, 3 and 1 (each within the scatter of the next). At a limit, above all of these: compound 4.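

Compound 4 stands at a limit of the assay and not at a number, so its true value is not known: the limit of > 100000 nM in this assay, at which 1 of the 4 values shown sits.

Even so, this assay gives a clear reading of the step, an at least 8.6-fold higher number from compound 3 to compound 4 (0.93 log units; beyond the scatter), and this is the first change in the set that moves beyond the scatter, towards a weaker inhibitor. Compounds 1, 2 and 3 showed that methoxy, pentyl and heptyloxy could be exchanged on the aromatic ring with no change beyond the scatter, whereas undecyl on a saturated chain carbon, seven bonds along the chain from an oxygen on an aromatic ring, shows that this tolerance of chain growth has an end.

The compounds shown leave open where, on the way from the heptyloxy chain of compound 3 to the much longer chain of compound 4, the value starts to climb, as a decyloxy or a dodecyloxy group might reveal. They also leave open whether a chain of similar reach ending in an amine or a carboxylic acid would behave in the same way.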